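The compounds below may be only part of what the source reports. "The series", "measured", "known", "first", "only" and "open" are said of these compounds alone.

Measured so far:
compound 1 `Fc1ccc2nc(NC(=S)Nc3ccc(Cl)cc3)sc2c1` — 18700 nM
compound 2 `Fc1ccc(NC(=S)Nc2nc3ccc(F)cc3s2)cc1` — 16200 nM
compound 3 `Fc1ccc2nc(Nc3nc4ccc(Cl)cc4s3)sc2c1` — > 50000 nM, a limit of the assay

In a functional assay on U-937 cells (Homo sapiens) for cytotoxicity, read by MTT assay, with a stated time of 48 h (a higher number here means a weaker inhibitor, a lower number a stronger inhibitor), compound 1 gives 18700 nM and compound 2 gives 16200 nM. The change between them is fluoro in place of chloro on an aromatic carbon, and it produced a 1.2-fold lower number from compound 1 to compound 2 (0.06 log units; within the scatter). For compound 3 this assay reports only a limit, > 50000 nM (the limit of > 50000 nM in this assay, at which 1 of the 3 values shown sits). The difference between the core of compound 3 and the core of compound 1 is not broken down here.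

Compound 4 `Fc1ccc2nc(Nc3nc4ccc(F)cc4s3)sc2c1` is not yet measured. It differs from compound 3 by fluoro in place of chloro on an aromatic carbon, the same kind of change as in the measured pair, though here the place is part of a fused or bridged system of two rings, meta to a fused ring and para to a fused ring, rather than para to a large group. The step is expected to be a step that the limit leaves unreadable from compound 3 to compound 4, because a 1.2-fold lower number from compound 1 to compound 2 (0.06 log units; within the scatter) stayed within the scatter. Compound 4 is estimated at 70000 nM, between 35000 nM and 200000 nM, most likely again reported as a limit.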

Compound 4, half-maximal inhibitory concentration: 27400 nM
For compound 4 the middle estimate is 2.6-fold (0.41 log units) above the measured one; measured number outside the range, below it.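

In this assay, among the compounds shown here, fluoro in place of chloro on the second core gives an at least 1.8-fold lower number from compound 3 to compound 4 (0.26 log units; that floor lies within the scatter) as the only reading of the step. Compound 3 gives > 50000 nM as a limit of the assay, not a number. The change can therefore be set on both cores, but it cannot be said whether it behaves alike or differently on them: the same change on two cores in this assay, a 1.2-fold lower number (0.06 log units; within the scatter) from compound 1 to compound 2 and an at least 1.8-fold lower number (0.26 log units; that floor lies within the scatter) from compound 3 to compound 4; the limit leaves it open whether they differ.

On these data alone, the true size of the step on the core of compound 3 stays open. The compounds shown also leave open what other groups at this place, such as an amine or a carboxylic acid, would do to the number in this assay on either core.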